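This account rests on a few compounds, and the source may have more. Where it says the series, first, only, none or still open, it means among the compounds named here.

Compound 3 `COc1ccc(Cn2c(NCCNC(=N)N)nc(=O)n(Cc3ccc(C)cc3)c2=O)cc1` gives 0.0044 nM in a functional assay on the whole organism (strain C57Bl/6) for inhibition, with Mus musculus as the target, with a stated time of 180 min, at 48 degrees C; on this read-out lower numbers stand for an effect already at smaller amounts and higher numbers for an effect only at larger amounts of compound. It stands second highest of the three numbers measured there: compound 2 `COc1ccc(Cn2c(NCCNC(=N)N)nc(=O)n(Cc3ccc(Cl)cc3)c2=O)cc1` gives 0.004 nM, and the two lie within the scatter of each other, while compound 1 `COc1ccc(Cn2c(NCCNC(=N)N)nc(=O)n(Cc3ccc([N+](=O)[O-])cc3)c2=O)cc1` gives 0.048 nM, a number an 11-fold lower number from compound 1 to compound 3 (1.04 log units; beyond the scatter) away. Compound 4 `COc1ccc(Cn2c(NCCNC(=N)N)nc(=O)n(Cc3ccc(I)cc3)c2=O)cc1` differs from compound 3 by iodo in place of methyl on an aromatic carbon. The step that bears on it is a 1.1-fold higher number from compound 2 to compound 3 (0.04 log units; within the scatter), and a 12-fold lower number from compound 1 to compound 2 (1.08 log units; beyond the scatter) shows that a halogen at this place sits far from the nitro compound. Since an exchange of methyl for chloro at this aromatic carbon left the number unchanged, no step beyond the scatter is expected for iodo either, so a 1.1-fold lower number from compound 3 to compound 4 (0.04 log units; within the scatter) is the estimate. Compound 4 is thus expected to give 0.004 nM, between 0.0015 nM and 0.012 nM.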

Compound 4, half-maximal effective concentration: 0.051 nM
The estimate for compound 4 lay 13-fold (1.11 log units) below the measured number; measured number above the stated range.
By their numbers in this assay, from the lowest: compounds 2 and 3 (each within the scatter of the next); then compounds 1 and 4 (each within the scatter of the next).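

In this assay, this aromatic carbon proves sensitive to the group it carries, which the matching numbers for chloro and methyl had not suggested: iodo brings a 12-fold higher number from compound 3 to compound 4 (1.06 log units; beyond the scatter) and a 13-fold higher number from compound 2 to compound 4 (1.11 log units; beyond the scatter). Iodo instead falls level with nitro, at a 1.1-fold higher number from compound 1 to compound 4 (0.03 log units; within the scatter), so the four groups form two pairs, chloro with methyl and iodo with nitro. No available evidence accounts for this split. Going by these compounds, it remains open whether bromo, fluoro or an amine at this carbon would fall with compound 2 and compound 3 or with compound 1 and compound 4.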